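This account rests on a few compounds, and the source may have more. Where it says the series, first, only, none or still open, it means among the compounds named here.

Measured compounds in a functional assay on HepG2 cells (Homo sapiens) for antiproliferative activity, read by CCK-8 assay, with a stated time of 72 h; a higher number here means a weaker inhibitor, a lower number a stronger inhibitor:
compound 1 `O=C(/C=C/c1ccc(COc2ccccc2)cc1)NO`, 8400 nM
compound 3 `Nc1ccccc1NC(=O)c1ccc(COc2ccc(F)cc2)cc1`, 3840 nM
compound 2 `Nc1cnccc1NC(=O)/C=C/c1ccc(COc2ccccc2)cc1`, which reaches only a limit of this assay, > 32000 nM

Compound 3 holds the lowest of the two numbers shown, with compound 1 a step away from it. Compound 2 sits at the limit recorded by the limit of > 32000 nM in this assay, at which 1 of the 3 values shown sits. For the measured compounds named here, the one measured step, an at least 3.8-fold higher number from compound 1 to compound 2 (0.58 log units; beyond the scatter), concerns the amide-type nitrogen and leaves the phenoxy ring untouched. Compound 4 `Nc1ccccc1NC(=O)c1ccc(COc2ccc([N+](=O)[O-])cc2)cc1` differs from compound 3 elsewhere: nitro in place of fluoro on an aromatic carbon. Going by the values given here, no measured pair changes a substituent on that ring, so no step bears directly on this change. A step within the usual scatter is therefore expected, a 1.1-fold lower number from compound 3 to compound 4 (0.04 log units; within the scatter). Compound 4 is estimated at 3500 nM, with a range from 1200 nM to 10000 nM.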

Compound 4, half-maximal inhibitory concentration: > 32000 nM
Compound 4 ended at the assay's limit; the forecaster's own chance of this, stated with the estimate: 5%; middle value at least 9.1-fold (0.96 log units) from the limit.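

Substitution on the phenoxy ring, untouched in the earlier step, matters in this assay: on the aromatic carbon para to a large group, going from 4-fluorophenyl to 4-nitrophenyl gives an at least 8.3-fold higher number from compound 3 to compound 4 (0.92 log units; beyond the scatter). This rests on a single pair, so it describes this change only. Compound 4 stands at a limit, which is not a number, so the full size of the step stays unknown: the limit of > 32000 nM in this assay, at which 2 of the 4 values shown sit.

On these data alone, whether the loss belongs to nitro alone or to any group other than fluoro at this position stays open. An amine or a methoxy group on the same carbon would separate the two.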